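Chloro for Fluoro in a Urea Cytotoxicity Series

The compounds below may be only part of what the source reports. "The series", "measured", "known", "first", "only" and "open" are said of these compounds alone.

Measured compounds:
compound 1, `CCN(CC)CCCNc1nc(-c2ccc(NC(=O)Nc3ccccc3F)cc2)nc2ccsc12`, 370 nM
compound 2, `CCN(CC)CCCNc1nc(-c2ccc(NC(=O)Nc3ccccc3Cl)cc2)nc2ccsc12`, 200 nM
compound 3, `CCN(CC)CCNc1nc(-c2ccc(NC(=O)Nc3ccc(F)cc3)cc2)nc2c(Cl)c(Cl)sc12`, 500 nM

All three were tested in a functional assay on NCI-H460 cells (Homo sapiens) for cytotoxicity, read by MTT assay, with a stated time of 72 h; a higher number here means a weaker inhibitor, a lower number a stronger inhibitor. Compound 2 differs from compound 1 by chloro in place of fluoro on an aromatic carbon, and this gave a 1.9-fold lower number from compound 1 to compound 2 (0.27 log units; within the scatter). Compound 3 carries a different core from compound 1; the difference between the two cores is not broken down here. Compound 4, `CCN(CC)CCNc1nc(-c2ccc(NC(=O)Nc3ccc(Cl)cc3)cc2)nc2c(Cl)c(Cl)sc12`, is not yet measured; it differs from compound 3 by chloro in place of fluoro on an aromatic carbon. Going by the values given here, the change is of the same kind as the one from compound 1 to compound 2, but not the same: there the chloro sits ortho to a large group, here para to a large group. The expected step is a 1.7-fold lower number from compound 3 to compound 4 (0.22 log units; within the scatter), a size resting on the earlier step of a 1.9-fold lower number from compound 1 to compound 2 (0.27 log units; within the scatter), with added uncertainty from the different core and place. Compound 4 is therefore expected to give about 300 nM in this assay, in a range from 120 nM to 750 nM.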

Compound 4, half-maximal inhibitory concentration: 320 nM
The estimate for compound 4 lay 1.1-fold (0.03 log units) below the measured number, and the stated range covers the measured number.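

In this assay, chloro in place of fluoro gave a 1.6-fold lower number from compound 3 to compound 4 (0.19 log units; within the scatter), and the change carried to the second core with a step of much the same size: the same change on two cores in this assay, a 1.9-fold lower number (0.27 log units; within the scatter) from compound 1 to compound 2 and a 1.6-fold lower number (0.19 log units; within the scatter) from compound 3 to compound 4, 1.2-fold (0.07 log units) apart, within the scatter of two such steps. Each step alone lies within the scatter, so the two pairs agree with each other but do not establish that this change alters the number on either core. The pairs also differ in both core and place on the ring, so two pairs cannot separate the influence of one from the other.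

Going by these compounds, it remains open whether bromo or trifluoromethyl in place of chloro would follow the same course. On these data alone, it is equally open whether the step would hold with a morpholine at the end of the side chain.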